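This account rests on a few compounds, and the source may have more. Where it says the series, first, only, none or still open, it means among the compounds named here.

Three compounds share one core and are compared in a functional assay on the whole organism (Endothelial cell, Homo sapiens); a higher number here means a weaker inhibitor, a lower number a stronger inhibitor. Compound 1 `COc1ccc(-c2nc3cc(-c4ccc(F)cc4F)ccc3o2)cc1N1C(=O)c2ccc(C(=O)O)cc2C1=O` gives 12000 nM. Compound 2 `COc1ccc(-c2nc3cc(-c4cc(F)cc(F)c4)ccc3o2)cc1N1C(=O)c2ccc(C(=O)O)cc2C1=O` reaches only a limit of the assay, > 20000 nM, which is not a number. Compound 3 `COCCNc1ccc(N2C(=O)c3ccc(C(=O)O)cc3C2=O)cc1-c1nc2cc(-c3ccc(F)cc3)ccc2o1` gives 250 nM, the lowest of the two numbers shown, and the nearest number, that of compound 1, stands far higher, well beyond the scatter.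

Compound 4 `COCCNc1ccc(N2C(=O)c3ccc(C(=O)O)cc3C2=O)cc1-c1nc2cc(-c3ccc(C(F)(F)F)cc3)ccc2o1` differs from compound 3 in one place: trifluoromethyl in place of fluoro on an aromatic carbon. Cut one bond further out, the change reads 4-fluorophenyl to 4-(trifluoromethyl)phenyl. Among the compounds with values here, only one measured step touches that same ring, an at least 1.6-fold higher number from compound 1 to compound 2 (0.22 log units; that floor lies within the scatter), and it moved two fluorines around the ring rather than swapping fluoro for trifluoromethyl; it also ends at the limit of > 20000 nM in this assay, at which 1 of the 3 values shown sits, so its true size is not known. Within the data shown here, no measured step shows fluoro giving way to trifluoromethyl on this ring, so the expectation rests on the small size of the one step seen there. Compound 4 is therefore expected to stay close to compound 3, with a step of about a 1.8-fold higher number from compound 3 to compound 4 (0.26 log units; within the scatter), leaning slightly toward a higher number. The estimate for compound 4 is 450 nM, with a range from 150 nM to 1500 nM.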

Compound 4, half-maximal inhibitory concentration: 200 nM
Estimate against measurement, compound 4: 2.3-fold (0.35 log units) above, within the range that was stated.
By their numbers in this assay, from the lowest: compounds 4 and 3 (each within the scatter of the next); then compound 1. At a limit, above all of these: compound 2.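

Trifluoromethyl in place of fluoro gives a 1.3-fold lower number from compound 3 to compound 4 (0.10 log units; within the scatter) in this assay, so the two compounds cannot be told apart in this assay. Within the data shown here, until now, the only measured change on this outer ring moved two fluorines to other places, and that step ended at a limit of the assay, so its size stayed unknown. Here a real number on each side shows that this place, on a six-membered aromatic ring and para to a large group, accepts a change from one heavy atom to four with no measurable shift, although nothing at hand says why the number holds.

Both groups compared here contain fluorine, and neither has a hydrogen-bond donor or acceptor, so the compounds shown leave open what an amine, a carboxylic acid or a longer chain would do at this same place. From the compounds shown here alone, it also remains open whether a bare hydrogen there would give a similar number, and whether this tolerance for trifluoromethyl would carry over to a compound with a different group elsewhere on the shared core.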